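The source may hold more compounds than are shown below. What is called first, only, known or untested is meant among the compounds shown, and "the series" means these compounds.

Compound 1 `CCOCCn1c(N2CCN(C)CC2)nc2ccccc21` gives 10 nM in a functional assay on ileum for inhibition of histamine H1 receptor (Cavia porcellus); a lower number here means a stronger inhibitor, a higher number a weaker inhibitor.
Compound 2 `CCCN1CCN(c2nc3ccccc3n2CCOCC)CC1` gives 16 nM in this assay.
Compound 3 `CCOCCn1c(N2CCN(c3ccccc3)CC2)nc2ccccc21` gives only a limit in this assay, > 10000 nM, not a number.

Compound 3 therefore stands at the weak end of everything measured so far: the step of an at least 1000-fold higher number from compound 1 to compound 3 (3.00 log units; beyond the scatter) and the step of an at least 620-fold higher number from compound 2 to compound 3 (2.79 log units; beyond the scatter) both run far beyond the scatter, and the limit of > 10000 nM in this assay, at which 1 of the 3 values shown sits, marks where compound 3 sits. Compound 4 `CCCCCN1CCN(c2nc3ccccc3n2CCOCC)CC1` is not yet measured. It differs from compound 3 in one place: pentyl in place of phenyl on an amine nitrogen in a ring. The two measured steps that bear on this change run in the opposite direction: placing phenyl on that ring nitrogen in place of methyl or of propyl raised the number greatly, so putting a chain back in place of phenyl is expected to lower it sharply. Whether pentyl behaves like methyl or like propyl is not shown; between those two chains, the step of a 1.6-fold higher number from compound 1 to compound 2 (0.20 log units; within the scatter) stayed within the scatter. For compound 4 a large drop, an at least 330-fold lower number from compound 3 to compound 4 (2.52 log units; beyond the scatter), is expected. The estimate for compound 4 is 30 nM, with a range from 8 nM to 150 nM.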

Compound 4, half-maximal inhibitory concentration: 30 nM
For compound 4 middle estimate and measured number coincide at the digits printed; the measured number falls inside the stated range.
By their numbers in this assay, from the lowest: compounds 1, 2 and 4 (each within the scatter of the next, the first and the last beyond it). At a limit, above all of these: compound 3.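

In this assay the swap of phenyl for pentyl on this ring nitrogen gives an at least 330-fold lower number from compound 3 to compound 4 (2.52 log units; beyond the scatter) and shows that a group of similar heavy-atom count, 5 against 6, can sit here when it is an open chain with no ring. For compound 3 the starting point of that step is a limit and not a number: the limit of > 10000 nM in this assay, at which 1 of the 4 values shown sits. Among the chains, propyl and pentyl cannot be told apart, with a 1.9-fold higher number from compound 2 to compound 4 (0.27 log units; within the scatter) inside the scatter, while methyl and pentyl do separate, though only modestly, with a 3.0-fold higher number from compound 1 to compound 4 (0.48 log units; beyond the scatter) as their step.

From the compounds shown here alone, it remains open whether a chain longer than pentyl would hold up as well. Also open, going by these compounds, is whether benzyl, with its ring set one carbon away from the nitrogen, would behave like phenyl or like the chains.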